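Replacing the aryl group on the ring nitrogen of compound 1

The source may report more compounds than this note shows. Statements on the series, on what has been measured and on what is new or still open speak of the compounds shown alone.

Compound 1 `COc1ccc(N2CCN(Cc3csc(N)c3C(=O)c3ccc(Cl)cc3)CC2)cc1` carries a 4-methoxyphenyl group on an amine nitrogen in a ring. In a functional assay on CHO cells with adenosine receptor A1 (Homo sapiens) as the target, read by cAMP accumulation and immunoassay, with a stated time of 6 min, tested at 10 uM (on this read-out lower numbers stand for a stronger effect and higher numbers for a weaker effect at the one concentration tested), compound 1 gives -52%, the highest of the three numbers measured and therefore the weakest effect among them. Compound 2 `Nc1scc(CN2CCN(c3c(F)cc(F)cc3F)CC2)c1C(=O)c1ccc(Cl)cc1` gives -78%, and compound 3 `Nc1scc(CN2CCN(c3ccc(F)c(Cl)c3)CC2)c1C(=O)c1ccc(Cl)cc1` gives -78%. The shift a number 26 percentage points lower from compound 1 to compound 2 (beyond the scatter) and the shift a number 26 percentage points lower from compound 1 to compound 3 (beyond the scatter) both arose from exchanging the 4-methoxyphenyl for another aromatic ring, and between the two halogenated analogues there is no change at the digits printed from compound 2 to compound 3 (within the scatter).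

Compound 4 `Nc1scc(CN2CCN(CCCc3ccc(Cl)cc3)CC2)c1C(=O)c1ccc(Cl)cc1` differs from compound 1 in one place: 3-(4-chlorophenyl)propyl in place of 4-methoxyphenyl on an amine nitrogen in a ring. The two measured steps swapped one aromatic ring for another, whereas here a 3-(4-chlorophenyl)propyl chain takes the place of the aromatic ring, so they bear on this change only loosely. As both steps lowered the number by a modest amount, a step of similar direction and size is expected here, with wide uncertainty. Compound 4 is expected to give -70%, within a range from -100% to -35%. This amounts to an estimated step of a number 18 percentage points lower from compound 1 to compound 4 (beyond the scatter).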

Compound 4, a percentage reported as activity, at one concentration (the size of the read-out at that concentration, not a potency): -76%
Estimate against measurement, compound 4: 6 percentage points above; the range from low to high includes it.
By their numbers in this assay, from the lowest: compounds 2, 3 and 4 (each within the scatter of the next); then compound 1.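

The earlier compounds shown here all carry an aromatic ring directly on the ring nitrogen, whereas the 3-(4-chlorophenyl)propyl chain of compound 4 holds its ring further out, and in this assay this change still gives a number 24 percentage points lower from compound 1 to compound 4 (beyond the scatter). Compared with the halogenated analogues, the steps are a number 2 percentage points higher from compound 3 to compound 4 (within the scatter) and a number 2 percentage points higher from compound 2 to compound 4 (within the scatter), so all three replacements of the 4-methoxyphenyl give values that these numbers do not separate. No measured evidence is available here to explain the shift from compound 1.

The compounds shown leave open how far the result depends on chain length, as a benzyl group or a longer chain would test, and whether the chlorine on the chain's ring matters. They also leave open whether a group with no aromatic ring, such as a plain butyl chain or a carboxylic acid, would give a similar number at this position.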